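Dimethylphenyl for dichlorophenyl on the shared core

This account rests on a few compounds, and the source may have more. Where it says the series, first, only, none or still open, it means among the compounds named here.

The read-out throughout is an ADME assay on microsomes from liver (Rattus norvegicus) for metabolic stability, read by LC-MS, using NADPH, at 37 degrees C; on this read-out lower numbers stand for a shorter-lived compound and higher numbers for a longer-lived compound. Compound 1, `Cc1oc(-c2ccc(Cl)c(Cl)c2)nc1CN1CCC(C(=O)NCCCN2C[C@H](C)C[C@H](C)C2)CC1`, gives > 0.5 h in this assay, and that reading is a limit of the assay rather than a number. Compound 3, `Cc1ccccc1-c1nc(CN2CCC(C(=O)N3CCN(CCN(C)C)CC3)CC2)c(C)o1`, likewise gives > 0.5 h in this assay, again a limit and not a number. Compound 2, `Cc1cccc(Cl)c1-c1nc(CN2CCC(C(=O)NCCCN3CCCC(C)C3)CC2)c(C)o1`, gives a number in this assay, 0.09 h. Compound 1 thus stands at the boundary shared by two of the three readings, (the limit of > 0.5 h in this assay, at which 2 of the 3 values shown sit), and no order between compound 1 and compound 3 can be drawn from it; the reading of compound 2 is the only one that sits as a number beneath that boundary.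

Compound 4, `Cc1cc(C)cc(-c2nc(CN3CCC(C(=O)NCCCN4C[C@H](C)C[C@H](C)C4)CC3)c(C)o2)c1`, differs from compound 1 in one place: 3,5-dimethylphenyl in place of 3,4-dichlorophenyl on an aromatic carbon. Among the compounds with values here, no pair among the measured compounds differs only in this way, so no measured step of this kind is available, and the three readings give no pattern that bears on the change. The working expectation is a modest drop from compound 1, an at least 1.2-fold lower number from compound 1 to compound 4 (0.09 log units; that floor lies within the scatter), which may or may not exceed the scatter. Compound 4 is accordingly estimated at 0.4 h in this assay, within a range of 0.12 h to 1 h.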

Compound 4, half-life: < 0.5 h
Compound 4 ended at the assay's limit; the forecaster's own chance of this, stated with the estimate: 40%; the middle value lies beyond the limit too.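

In this assay compound 4 gives < 0.5 h, which is a limit of the assay and not a number. Replacing 3,4-dichlorophenyl with 3,5-dimethylphenyl on this aromatic carbon of the five-membered ring gives the only one-place step shown in the series, and it reads a number no higher from compound 1 to compound 4 (the limit leaves the size open). The change therefore carries the reading across the boundary of the assay, from the side shared by compound 1 and compound 3 to the side held by compound 4 alone: the limit of < 0.5 h in this assay, at which 1 of the 4 values shown sits.

From the compounds shown here alone, how far compound 1 and compound 4 each lie from that boundary remains open, so neither the size of the change nor its relation to the usual scatter can be told from these two readings. Also open, going by these compounds, is whether a pyridyl or a trifluoromethylphenyl group on the same carbon of the shared core would read on the side of compound 1 or on that of compound 4.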